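This account rests on a few compounds, and the source may have more. Where it says the series, first, only, none or still open, it means among the compounds named here.

Measured in a functional assay on MCF7 cells (Homo sapiens) for antiproliferative activity, read by MTT assay, with a stated time of 72 h; a higher number here means a weaker inhibitor, a lower number a stronger inhibitor:
- Compound 1 `O=C(COc1ccc(C(=O)/C=C/c2ccc(F)cc2)cc1)N[C@H]1CCOC1=O`: > 64000 nM, a limit of the assay
- Compound 2 `O=C(COc1ccc(C(=O)/C=C/c2ccccc2Br)cc1)N[C@H]1CCOC1=O`: 15300 nM

Among the measured compounds shown here, compound 2 holds the only actual number so far, as the other result is the limit of > 64000 nM in this assay, at which 1 of the 2 values shown sits.

Next is compound 3 `O=C(COc1ccc(C(=O)/C=C/c2ccc(Br)cc2)cc1)N[C@H]1CCOC1=O`, not yet measured, which has 4-bromophenyl in place of 2-bromophenyl on a double-bonded chain carbon bound to a double-bonded chain carbon.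

For the measured compounds named here, one measured step bears on this: an at least 4.1-fold lower number from compound 1 to compound 2 (0.62 log units; beyond the scatter). That step changes the halogen and its place together, so it cannot isolate the effect of place alone. Compound 3 keeps the bromine of compound 2 but shares the 4-substitution of compound 1, so some loss in this assay is expected, smaller than the gain in that step.

The expected change is a 1.6-fold higher number from compound 2 to compound 3 (0.20 log units; within the scatter), toward a higher number.

For compound 3 the estimate is 24000 nM, with an expected range of 8000 nM to 64000 nM.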

Compound 3, half-maximal inhibitory concentration: > 64000 nM
Compound 3: only a limit was reported; the forecaster's own chance of this, stated with the estimate: 25%; middle value at least 2.6-fold (0.42 log units) from the limit.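

In this assay, replacing 2-bromophenyl with 4-bromophenyl, with the same atoms joined differently, gives an at least 4.1-fold higher number from compound 2 to compound 3 (0.62 log units; beyond the scatter). The earlier step changed the halogen and its place together, whereas this one changes the place of the bromine alone and shows that place by itself matters on this aryl group. Compound 1 and compound 3 both stand at the assay limit, so the step between them cannot be read and bromo in place of fluoro stays unresolved: the limit of > 64000 nM in this assay, at which 2 of the 3 values shown sit.

Open, as far as these compounds go, is whether the number of compound 2 depends on bromine itself, which chlorine or a methoxy group in place of the bromine of 2-bromophenyl would test. Also open, from the compounds shown here alone, is whether a pyridine ring in place of the phenyl ring on the same chain carbon would keep a measurable number.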